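From a catechol hydrazone to a hydroxynaphthyl analogue

The compounds below may be only part of what the source reports. "The series", "measured", "known", "first", "only" and "open" are said of these compounds alone.

Three compounds sharing one core were tested in a functional assay on U-87MG ATCC cells (Homo sapiens) for cytotoxicity, read by MTT assay, with a stated time of 72 h; on this read-out higher numbers stand for weaker inhibition and lower numbers for stronger inhibition. Compound 1 `CN(C)CCn1cnnc1-c1cc(Oc2ccc(NC(=O)N/N=C/c3ccc(O)c(Br)c3)cc2F)ccn1` gives 12400 nM, and compound 2 `COc1ccc(/C=N/NC(=O)Nc2ccc(Oc3ccnc(-c4nncn4CCN(C)C)c3)c(F)c2)c(OC)c1OC` gives 7650 nM; between them, a 1.6-fold lower number from compound 1 to compound 2 (0.21 log units; within the scatter). Compound 3 `CN(C)CCn1cnnc1-c1cc(Oc2ccc(NC(=O)N/N=C/c3ccc(O)c(O)c3)cc2F)ccn1`, which carries a 3,4-dihydroxyphenyl on the carbon with a double bond to nitrogen, reaches only a limit of this assay, > 100000 nM. Compound 3 therefore stands at the weak end of the three: it sits at the limit of > 100000 nM in this assay, at which 1 of the 3 values shown sits, and the two steps leading to it, an at least 8.0-fold higher number from compound 1 to compound 3 (0.90 log units; beyond the scatter) and an at least 13-fold higher number from compound 2 to compound 3 (1.11 log units; beyond the scatter), both run beyond the scatter toward weaker inhibition.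

Compound 4 `CN(C)CCn1cnnc1-c1cc(Oc2ccc(NC(=O)N/N=C/c3c(O)ccc4ccccc34)cc2F)ccn1` differs from compound 3 by 2-hydroxynaphthalen-1-yl in place of 3,4-dihydroxyphenyl on a carbon with a double bond to nitrogen. Both measured steps that bear on this position show that exchanging the 3,4-dihydroxyphenyl for another aryl group, as in compounds 1 and 2, lowers the number well beyond the scatter. Going by the values given here, by that reasoning compound 4 is expected to move in the same direction, an at least 6.6-fold lower number from compound 3 to compound 4 (0.82 log units; beyond the scatter), though with only three compounds the size remains uncertain. Compound 4 is accordingly estimated at 15000 nM, within 4000 nM to 60000 nM.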

Compound 4, half-maximal inhibitory concentration: 620 nM
Beside the measured number, compound 4's estimate is 24-fold (1.38 log units) above it; the whole stated range lies above it.
By their numbers in this assay, from the lowest: compound 4; then compounds 2 and 1 (each within the scatter of the next). At a limit, above all of these: compound 3.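

With 2-hydroxynaphthalen-1-yl on the carbon with a double bond to nitrogen, the group at this position separates compound 4 from both measured aryl analogues, a 12-fold lower number from compound 2 to compound 4 (1.09 log units; beyond the scatter) and a 20-fold lower number from compound 1 to compound 4 (1.30 log units; beyond the scatter), whereas the values of compounds 1 and 2 had stayed within the scatter of each other. The change from 3,4-dihydroxyphenyl is larger still, an at least 160-fold lower number from compound 3 to compound 4 (2.20 log units; beyond the scatter). The value of compound 3 is only a limit, so the full size of that step stays unknown: the limit of > 100000 nM in this assay, at which 1 of the 4 values shown sits.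

Only compound 4 carries 2-hydroxynaphthalen-1-yl, so the compounds shown do not tell whether its lower number goes with the two rings or with the hydroxy group. On these data alone, how a plain naphthyl group, or a methoxy or an amine in place of that hydroxy, would read in this assay remains open.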